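Amide side chains and antiproliferative activity in one series

A few compounds are considered here, and "the series" means these few. Any claim that something is new, unique, unknown or untested is made for them only; others in the source may bear on it.

Values from a functional assay on BXPC-3 cells (Homo sapiens) for antiproliferative activity, read by MTT assay, with a stated time of 24 h (a higher number here means a weaker inhibitor, a lower number a stronger inhibitor), for the measured compounds:
- compound 1 `CCn1c(C(=O)NCCC(=O)OC)ccc1C(CC)(CC)c1ccc(OCS(=O)(=O)c2ccccc2)c(C)c1` gives > 50000 nM
- compound 2 `CCn1c(C(=O)N[C@H](C)CO)ccc1C(CC)(CC)c1ccc(OCS(=O)(=O)c2ccccc2)c(C)c1` gives 10000 nM
- compound 3 `CCn1c(C(=O)N[C@H](CO)C(C)C)ccc1C(CC)(CC)c1ccc(OCS(=O)(=O)c2ccccc2)c(C)c1` gives 7720 nM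

Compound 1 has > 50000 nM as its entry, which is a limit of the assay and not a number. Compound 3 stands level with compound 2, as the step between them shows (a 1.3-fold lower number from compound 2 to compound 3 (0.11 log units; within the scatter)). Compound 4 `CCn1c(C(=O)N[C@@H](CO)CCCO)ccc1C(CC)(CC)c1ccc(OCS(=O)(=O)c2ccccc2)c(C)c1` keeps the shared core and alters only the amide side chain (a group of 7 heavy atoms (5 carbon, 2 oxygen; no ring) in place of a group of 6 heavy atoms (5 carbon, 1 oxygen; no ring), on an amide-type nitrogen). The 1-(hydroxymethyl)-2-methylpropyl group leaves, and a group with no common name enters. The larger steps, an at least 5.0-fold lower number from compound 1 to compound 2 (0.69 log units; beyond the scatter) and an at least 6.4-fold lower number from compound 1 to compound 3 (0.81 log units; beyond the scatter) in turn, both start from the 2-(methoxycarbonyl)ethyl group, so they bear less directly on this change. The closest guide is the step among hydroxymethyl-bearing side chains (a 1.3-fold lower number from compound 2 to compound 3 (0.11 log units; within the scatter)), so no step beyond the scatter is expected in this assay here. The expected change is small (a 1.2-fold higher number from compound 3 to compound 4 (0.07 log units; within the scatter)). Compound 4 is estimated at 9000 nM with an expected range from 3500 nM to 25000 nM in this assay.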

Compound 4, half-maximal inhibitory concentration: 16400 nM
For compound 4 the middle estimate is 1.8-fold (0.26 log units) below the measured one; low and high end bracket the measured number.
By their numbers in this assay, from the lowest: compounds 3, 2 and 4 (each within the scatter of the next, the first and the last beyond it). At a limit, above all of these: compound 1.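

In this assay, the change from the 1-(hydroxymethyl)-2-methylpropyl group to the new side chain gives a step that passes the scatter, a 2.1-fold higher number from compound 3 to compound 4 (0.33 log units; beyond the scatter), unlike the earlier step among hydroxymethyl-bearing side chains. Yet 2-hydroxyethyl in place of hydrogen on the saturated chain carbon does not clearly separate the new compound from the smaller side chain of compound 2, a 1.6-fold higher number from compound 2 to compound 4 (0.21 log units; within the scatter), while the step from the methyl ester side chain still stands beyond the scatter, an at least 3.0-fold lower number from compound 1 to compound 4 (0.48 log units; beyond the scatter). The entry for compound 1 is a limit and not a number, so that step has only a bound: the limit of > 50000 nM in this assay, at which 1 of the 4 values shown sits.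

The compounds shown leave open whether an amine or a carboxylic acid in place of the added hydroxyl would keep this level. They also leave open how the opposite configuration at the stereocentre would read.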